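The source may hold more compounds than are shown below. What is called first, only, known or untested is meant among the compounds shown, and "the series" means these compounds.

Measured compounds in an ADME assay on MT4 cells (Homo sapiens) for cytotoxicity, read by MTT assay; on this read-out lower numbers stand for higher toxicity in this test and higher numbers for lower toxicity in this test:
compound 1 `CCOC(=O)/C(O)=C/C(=O)c1cn(Cc2cc(F)c(F)c(F)c2)c2cccc(OC)c12` gives 33400 nM
compound 2 `CCOC(=O)/C(O)=C/C(=O)c1cn(Cc2ccc(F)c(F)c2)c2cccc(OC)c12` gives 125000 nM
compound 3 `CCOC(=O)/C(O)=C/C(=O)c1cn(Cc2c(F)cccc2F)c2cccc(OC)c12` gives 63400 nM

Compound 3 stands second highest of the three numbers in this assay, and its number is within the scatter of both compound 1 and compound 2, so no order among the three is claimed. Compound 4 `CCOC(=O)/C(O)=C/C(=O)c1cn(Cc2ccc(F)c(F)c2F)c2cccc(OC)c12` is not yet measured. It differs from compound 3 by 2,3,4-trifluorophenyl in place of 2,6-difluorophenyl on a saturated chain carbon bound to an aromatic nitrogen. Within the data shown here, two measured steps touch the same place: a 1.9-fold higher number from compound 1 to compound 3 (0.28 log units; within the scatter) and a 2.0-fold lower number from compound 2 to compound 3 (0.29 log units; within the scatter), both within the scatter. Among the measured compounds shown here, the only step beyond the scatter, a 3.7-fold higher number from compound 1 to compound 2 (0.57 log units; beyond the scatter), came from hydrogen in place of fluoro on the benzyl group, and raised the number. Compound 4 bears a 2,3,4-trifluorophenyl where compound 1 bears a 3,4,5-trifluorophenyl, and compound 1 and compound 3 differ only within the scatter. A step of that small size, if any, is therefore expected; the estimate for compound 4 means a 1.4-fold lower number from compound 3 to compound 4 (0.15 log units; within the scatter). Compound 4 is estimated at 45000 nM, with a range from 20000 nM to 100000 nM.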

Compound 4, half-maximal cytotoxic concentration: 42700 nM
Estimate against measurement, compound 4: 1.1-fold (0.02 log units) above, and the stated range covers the measured number.
By their numbers in this assay, from the lowest: compounds 1, 4, 3 and 2 (each within the scatter of the next, the first and the last beyond it).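

Within this assay, neither change among the fluoro patterns on the benzyl group separates the compounds: 2,3,4-trifluorophenyl in place of 2,6-difluorophenyl gives (a 1.5-fold lower number from compound 3 to compound 4 (0.17 log units; within the scatter)), and 2,3,4-trifluorophenyl in place of 3,4,5-trifluorophenyl gives (a 1.3-fold higher number from compound 1 to compound 4 (0.11 log units; within the scatter)), so the two trifluorophenyl arrangements cannot be told apart here. Fluoro in place of hydrogen on 3,4-difluorophenyl now gives a step beyond the scatter at a second carbon (a 2.9-fold lower number from compound 2 to compound 4 (0.47 log units; beyond the scatter)), matching the earlier step in size class (a 3.7-fold higher number from compound 1 to compound 2 (0.57 log units; beyond the scatter)), although compound 3, also a difluorophenyl, goes against a simple reading by fluoro count, lying within the scatter of compound 1, compound 2 and compound 4. No measurement at hand explains these numbers.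

Open, as far as these compounds go, is where a benzyl group bearing chloro or methoxy in place of fluoro would fall. Also open, from the compounds shown here alone, is whether a carboxylic acid in place of the ester would keep this pattern.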